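Working notes: propoxy to isopropoxy on the shared core

This account rests on a few compounds, and the source may have more. Where it says the series, first, only, none or still open, it means among the compounds named here.

Values in an ADME assay on HEK293 cells (Homo sapiens) for cytotoxicity, read by luminescence, with a stated time of 72 h (a lower number here means that less compound is needed, a higher number that more compound is needed for the effect), each of them a limit:
- compound 1 `CCOC(=O)c1c(-c2ccccc2)[nH]c2cc(OC)ccc2c1=O` gives > 22000 nM
- compound 2 `CCOC(=O)c1c(-c2cccc(OCC)c2)[nH]c2cc(OC)ccc2c1=O` gives > 22000 nM
- compound 3 `CCCOc1cccc(-c2[nH]c3cc(OC)ccc3c(=O)c2C(=O)OCC)c1` gives > 22000 nM

Compound 3 stands with no number of its own, since its > 22000 nM is a limit. The series as a whole offers only this: the limit of > 22000 nM in this assay, at which 3 of the 3 values shown sit. Compound 4 `CCOC(=O)c1c(-c2cccc(OC(C)C)c2)[nH]c2cc(OC)ccc2c1=O` is the next to be read, and the change is isopropyl in place of propyl on an oxygen on an aromatic ring.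

Within the data shown here, two measured steps bear most closely on this change: a step that the two limits leave unreadable from compound 1 to compound 3 and a step that the two limits leave unreadable from compound 2 to compound 3. A third gives no more: a step that the two limits leave unreadable from compound 1 to compound 2. None of them has a readable size, so no step beyond the scatter is expected in this assay, and no direction can be assigned. The expected step is a step that the limit leaves unreadable from compound 3 to compound 4. Compound 4 is estimated at 28000 nM, with an expected range of 15000 nM to 50000 nM.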

Compound 4, half-maximal effective concentration: > 22000 nM
Compound 4 was reported as a limit; the forecaster's own chance of this, stated with the estimate: 90%; the middle value is on the limit's open side.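

In this assay, among these compounds, compound 4 gives > 22000 nM, a limit, so no step between it and compound 1, compound 2 or compound 3 can be read. Whether these four compounds differ at all in this assay stays open, as every value shown is a limit: the limit of > 22000 nM in this assay, at which 4 of the 4 values shown sit.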